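Bromo for Nitro on a Caffeate Ester Scaffold

A few compounds are considered here, and "the series" means these few. Any claim that something is new, unique, unknown or untested is made for them only; others in the source may bear on it.

Compound 1 `CC1(C)C2CCC1(C)C(OC(=O)/C=C/c1ccc(O)c(O)c1)C2` gives 20600 nM in a functional assay on HeLa cells (Homo sapiens) for inhibition, read by MTT assay; on this read-out higher numbers stand for weaker inhibition and lower numbers for stronger inhibition.
Compound 2 `O=C(/C=C/c1ccc(O)c(O)c1[N+](=O)[O-])OCCc1ccccc1` gives 10900 nM in this assay.
Compound 3 `O=C(/C=C/c1cc(O)c(O)c([N+](=O)[O-])c1)OCCc1ccccc1` is recorded as "not determined" (no result reported) in this assay.

Compound 3 therefore stands without a number: no result was reported for it in this assay, and the two values available, from compound 1 and compound 2, belong to differently substituted esters and cannot be taken as its own. Compound 4 `O=C(/C=C/c1cc(O)c(O)c(Br)c1)OCCc1ccccc1` differs from compound 3 in one place: bromo in place of nitro on an aromatic carbon. Among the measured compounds shown here, no measured pair shows what this exchange does in this assay, so the size and direction of the step are unknown; the account expects a step no larger than the usual scatter of the read-out, in neither direction in particular. Because compound 2 gives 10900 nM and carries the same ester chain, the estimate for compound 4 is placed near that value. Compound 4 is expected to give about 10000 nM, estimated between 3000 nM and 40000 nM.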

Compound 4, half-maximal inhibitory concentration: 17500 nM
Beside the measured number, compound 4's estimate is 1.8-fold (0.24 log units) below it; the range from low to high includes it.
By their numbers in this assay, from the lowest: compounds 2, 4 and 1 (each within the scatter of the next).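

Among the compounds shown here, with no number for compound 3 to set against compound 4, no step between them can be read in this assay. The compounds shown leave open what bromo in place of nitro does on this read-out. No evidence at hand bears on this result.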